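Replacing an Ester End with a Chloro-Acid End

This account rests on a few compounds, and the source may have more. Where it says the series, first, only, none or still open, it means among the compounds named here.

The measured compounds and their results:
- compound 1, `COC(=O)c1ccc(OCCCCOc2ccc(C(=O)CC3CCCC3)c(C)c2C)cc1`: 14.1%
- compound 2, `COC(=O)c1ccc(OCCCCOc2ccc(C(=O)CC(C)C)c(C)c2C)cc1`: 15.9%
- compound 3, `COC(=O)c1ccc(OCCCCOc2ccc(C(=O)CC(C)C)c(O)c2C)cc1`: 16.4%

All three were tested in an assay on HEK293 cells for positive allosteric modulation of metabotropic glutamate receptor 2 (Rattus norvegicus), read by thallium flux, with a stated time of 2.5 min; on this read-out lower numbers stand for smaller maximal responses and higher numbers for larger maximal responses. Compound 2 gives 15.9%, the second highest of the three numbers. Its nearest neighbour is compound 3, with a number 0.5 percentage points higher from compound 2 to compound 3 (within the scatter), and its furthest is compound 1, with a number 1.8 percentage points higher from compound 1 to compound 2 (within the scatter); both steps lie within the usual scatter, so the three compounds cannot be told apart on this read-out.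

Compound 4, `Cc1c(OCCCCOc2ccc(C(=O)O)c(Cl)c2)ccc(C(=O)CC(C)C)c1C`, has not yet been measured. It differs from compound 2 at the far end of the chain: 4-carboxy-3-chlorophenyl in place of 4-(methoxycarbonyl)phenyl on an oxygen on a saturated carbon. Neither measured step touches this end of the molecule; both concern the carbonyl side chain or the ring bearing it. So no measured step bears directly on the change, and the only guide is that the measured compounds all sit close together. The step from compound 2 to compound 4 is therefore expected to be small, about a number 0.1 percentage points higher from compound 2 to compound 4 (within the scatter), with no direction favoured. Compound 4 is estimated to give 16%, in a range from 8% to 30%.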

Compound 4, largest response reached (reported as percent of maximum), in percent of the reference or control that the assay uses: 33.1%
For compound 4 the middle estimate is 17.1 percentage points below the measured one; the whole stated range lies below it.
By their numbers in this assay, from the lowest: compounds 1, 2 and 3 (each within the scatter of the next); then compound 4.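

In this assay, 4-carboxy-3-chlorophenyl in place of 4-(methoxycarbonyl)phenyl on an oxygen on a saturated carbon gives a number 17.2 percentage points higher from compound 2 to compound 4 (beyond the scatter), whereas the two earlier steps, made at the other end of the molecule, stayed within the scatter. This far end of the chain is therefore the first place in this small set where a change clearly moves the maximal response. The swap makes two changes at once, turning the methyl ester into a carboxylic acid and adding a chlorine, and nothing shown gives a reason for the rise.

The compounds shown leave open whether the acid, the chlorine or the two together account for the step, a question that a plain 4-carboxyphenyl end could help to settle. They also leave open how an amide or a tetrazole would behave at this end of the chain.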